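Adding fluoro to the unsubstituted chalcone-type compound 3

The source may report more compounds than this note shows. Statements on the series, on what has been measured and on what is new or still open speak of the compounds shown alone.

Measured in a functional assay on NCI-H727 cells (Homo sapiens) for cytotoxicity, with a stated time of 48 h; a higher number here means a weaker inhibitor, a lower number a stronger inhibitor:
- compound 1 `COc1cc(OC)c(C(=O)/C=C/c2ccccc2OC)c(OC)c1`: 4000 nM
- compound 2 `COc1cc(OC)c(C(=O)/C=C/c2ccccc2SC)c(OC)c1`: 8700 nM
- compound 3 `COc1cc(OC)c(C(=O)/C=C/c2ccccc2)c(OC)c1`: 11400 nM

Compound 3 sits at 11400 nM, level with compound 2 within the scatter, while compound 1 gives a clearly lower number. Compound 4 `COc1cc(OC)c(C(=O)/C=C/c2ccc(F)cc2)c(OC)c1` has fluoro in place of hydrogen on an aromatic carbon, para to a large group: fluoro in place of hydrogen on an aromatic carbon. For the measured compounds named here, no measured step involves fluoro. The nearest evidence is the exchange of hydrogen for another group on an aromatic carbon: a 2.9-fold higher number from compound 1 to compound 3 (0.45 log units; beyond the scatter) was modest, and a 1.3-fold higher number from compound 2 to compound 3 (0.12 log units; within the scatter) was not distinguishable from noise. A small change at most is therefore expected, and the expected step is a 1.3-fold lower number from compound 3 to compound 4 (0.13 log units; within the scatter). For compound 4 the estimated value is 8500 nM, within an expected range of 3800 nM to 19000 nM.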

Compound 4, half-maximal inhibitory concentration: 5500 nM
For compound 4 the middle estimate is 1.5-fold (0.19 log units) above the measured one; low and high end bracket the measured number.
By their numbers in this assay, from the lowest: compounds 1, 4, 2 and 3 (each within the scatter of the next, the first and the last beyond it).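

Fluoro in place of hydrogen on an aromatic carbon, para to a large group, gives a 2.1-fold lower number from compound 3 to compound 4 (0.32 log units; beyond the scatter) in this assay and this step is modest. The remaining steps read a 1.6-fold lower number from compound 2 to compound 4 (0.20 log units; within the scatter) and a 1.4-fold higher number from compound 1 to compound 4 (0.14 log units; within the scatter) and exchange a whole substituted phenyl, so they cannot be read as the effect of one group. No measurement here explains the fluoro step.

Going by these compounds, whether a larger halogen such as chloro, or an amine, at this place would act like fluoro stays open. So does whether fluoro added to compound 1 would combine with its methoxy.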